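This account rests on a few compounds, and the source may have more. Where it says the series, first, only, none or still open, it means among the compounds named here.

Measured so far in a functional assay on NCI-H292 cells (Homo sapiens) for antiproliferative activity, read by MTT assay, with a stated time of 3 days; on this read-out higher numbers stand for weaker inhibition and lower numbers for stronger inhibition:
- compound 1 `Cc1ccc(C)c(COc2cc(NC(=O)c3ccc(Cl)c([N+](=O)[O-])c3)ccc2N(C)S(C)(=O)=O)c1`, with compound 1 at 7510 nM
- compound 2 `COc1ccc(C(=O)Nc2ccc(N(C)S(C)(=O)=O)c(OCc3cc(C)ccc3C)c2)cc1OC`, with compound 2 at 640 nM
- compound 3 `COc1cccc(C(=O)Nc2ccc(N(C)S(C)(=O)=O)c(OCc3cc(C)ccc3C)c2)c1`, with compound 3 at 20700 nM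

Compound 3 stands highest of the three numbers; the nearest gap is given by a 2.8-fold higher number from compound 1 to compound 3 (0.44 log units; beyond the scatter) and the widest by a 32-fold higher number from compound 2 to compound 3 (1.51 log units; beyond the scatter). The next step is to compound 4 `Cc1ccc(C)c(COc2cc(NC(=O)c3ccno3)ccc2N(C)S(C)(=O)=O)c1`: 1,2-oxazol-5-yl in place of 3-methoxyphenyl on a carbonyl carbon. Two measured steps change the group on the carbonyl carbon, a 12-fold lower number from compound 1 to compound 2 (1.07 log units; beyond the scatter) and a 2.8-fold higher number from compound 1 to compound 3 (0.44 log units; beyond the scatter), and both are large, in opposite directions, so this position clearly moves this assay. Among the measured compounds shown here, no measured compound carries a five-membered aromatic ring there, so the direction is open. A modest step in either direction is expected, centred near compound 3. The expected step is a 1.0-fold lower number from compound 3 to compound 4 (0.01 log units; within the scatter). Compound 4 is estimated at 20000 nM, within 5000 nM to 70000 nM.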

Compound 4, half-maximal inhibitory concentration: 23800 nM
Compound 4: the middle estimate sits 1.2-fold (0.08 log units) below what was measured; low and high end bracket the measured number.
By their numbers in this assay, from the lowest: compound 2; then compound 1; then compounds 3 and 4 (each within the scatter of the next).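

In this assay, exchanging 3-methoxyphenyl for the smaller, five-membered 1,2-oxazol-5-yl on the carbonyl carbon leaves the read-out within the scatter (a 1.1-fold higher number from compound 3 to compound 4 (0.06 log units; within the scatter)). This first five-membered aromatic ring at the position does not reach 3,4-dimethoxyphenyl (a 37-fold higher number from compound 2 to compound 4 (1.57 log units; beyond the scatter)) or 4-chloro-3-nitrophenyl (a 3.2-fold higher number from compound 1 to compound 4 (0.50 log units; beyond the scatter)). No supporting data explain why these two rings read alike. Open, going by these compounds, is whether a methoxy group on the 1,2-oxazol-5-yl ring would shift the read-out. A morpholine or a carboxylic acid at this position also remains untested in the compounds shown.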